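This account rests on a few compounds, and the source may have more. Where it says the series, first, only, none or still open, it means among the compounds named here.

Compound 1: `Cc1ccc(NC(=O)CCN(Cc2ccc(C(=O)NO)cc2)C(=O)c2cc(C)cc(C)c2)cc1`, 670 nM
Compound 2: `CN(C)c1ccc(C(=O)N(CCC(=O)NCc2ccc(Cl)cc2)Cc2ccc(C(=O)NO)cc2)cc1`, 850 nM

In a functional assay on NB1 cells (Homo sapiens) for antiproliferative activity, with a stated time of 72 h (on this read-out higher numbers stand for weaker inhibition and lower numbers for stronger inhibition), compound 2 gives the higher of the two numbers, though its gap to compound 1 lies within the usual scatter. Compound 3, `Cc1ccc(NC(=O)CCN(Cc2ccc(C(=O)NO)cc2)C(=O)c2ccc(N(C)C)cc2)cc1`, has not been measured. It differs from compound 2 in one place: 4-methylphenyl in place of 4-chlorobenzyl on an amide-type nitrogen. Compound 1 carries the same 4-methylphenyl group on its amide nitrogen, and in this assay compound 1 gives 670 nM, so no step beyond the scatter is expected here. Compound 3 is therefore estimated at 700 nM, with a likely range from 350 nM to 1400 nM; the expected step is a 1.2-fold lower number from compound 2 to compound 3 (0.08 log units; within the scatter).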

Compound 3, half-maximal inhibitory concentration: 660 nM
Compound 3: the middle estimate sits 1.1-fold (0.03 log units) above what was measured, and the stated range covers the measured number.
By their numbers in this assay, from the lowest: compounds 3, 1 and 2 (each within the scatter of the next).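

Going by these compounds alone, with 4-methylphenyl in place of 4-chlorobenzyl on the amide-type nitrogen, this assay shows a 1.3-fold lower number from compound 2 to compound 3 (0.11 log units; within the scatter) as the first direct reading at this position, so the two groups cannot be told apart here. With 4-(dimethylamino)phenyl in place of 3,5-dimethylphenyl on the carbonyl carbon, it shows a 1.0-fold lower number from compound 1 to compound 3 (0.01 log units; within the scatter) and again no difference that can be read. Nothing at hand explains these results. Still open, on these data alone, is whether a longer chain, an amine or a carboxylic acid in the place of these groups would move the number beyond the scatter.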